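The compounds below may be only part of what the source reports. "The series", "measured", "known", "first", "only" and "open" are said of these compounds alone.

Measured compounds:
- compound 1, `O=C(NC(=S)Nc1nc2cc([N+](=O)[O-])ccc2s1)N1CCOCC1`: 31000 nM
- compound 2, `O=C(NC(=S)Nc1nc2ccccc2s1)c1ccc([N+](=O)[O-])cc1`: 33800 nM

Both compounds were tested in a functional assay on MCF7 cells (Homo sapiens) for cytotoxicity, read by MTT assay, with a stated time of 24 h; on this read-out higher numbers stand for weaker inhibition and lower numbers for stronger inhibition. Compound 1 gives 31000 nM in this assay, and compound 2 gives 33800 nM. Compound 2 holds the higher of the two numbers, but the gap to compound 1 lies within the scatter, so the two cannot be told apart on these data.

Compound 3, `O=C(NC(=S)Nc1nc2cc([N+](=O)[O-])ccc2s1)c1ccc([N+](=O)[O-])cc1`, has not yet been measured in this assay. It differs from compound 2 in one place: nitro in place of hydrogen on an aromatic carbon. Compound 2 already carries a nitro group on its benzoyl ring; in compound 3 a second nitro group enters on the six-membered carbon ring of the fused two-ring system, the position where compound 1 carries its nitro group.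

Among the compounds with values here, no step between measured compounds reports what this change does. Since compound 1 and compound 2, which carry one nitro group each at different places, give numbers within the scatter of one another, the expected step of a 1.2-fold lower number from compound 2 to compound 3 (0.08 log units; within the scatter) is small and not beyond the scatter in either direction. Compound 3 is therefore estimated at 28000 nM in this assay, within a range from 10000 nM to 75000 nM.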

Compound 3, half-maximal inhibitory concentration: 35200 nM
Compound 3: middle estimate off by 1.3-fold (0.10 log units), on the low side; the measured number falls inside the stated range.
By their numbers in this assay, from the lowest: compounds 1, 2 and 3 (each within the scatter of the next).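

In this assay, the nitro group that enters on the six-membered aromatic ring, part of the fused system of two rings, gives a 1.0-fold higher number from compound 2 to compound 3 (0.02 log units; within the scatter). Within the data shown here, this is the first direct reading of this change, and in this pair, where a 4-nitrophenyl group is already present, the step lies within the scatter, so the two compounds cannot be told apart. The second new pair compares 4-nitrophenyl in place of morpholin-4-yl on a carbonyl carbon, with the nitro group on the shared core kept in both compounds, and it gives a 1.1-fold higher number from compound 1 to compound 3 (0.06 log units; within the scatter), also within the scatter, while no measurement at hand explains either result.

What the compounds shown leave open is whether a different group at the same aromatic carbon, such as an amine or a carboxylic acid, would shift the number beyond the scatter. From the compounds shown here alone, it also remains open whether the same nitro step would read alike with morpholin-4-yl on the carbonyl carbon, or whether a longer chain there would change the reading.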